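The compounds below may be only part of what the source reports. "The series", "measured", "known", "first", "only" and "open" are said of these compounds alone.

Measured so far in a physicochemical assay for solubility, with a stated time of 12 h, at pH 6.8, tested at 10 mM; on this read-out higher numbers stand for higher solubility and lower numbers for lower solubility:
compound 1 `CN1CCc2nc(C(=O)Nc3cc(C(=O)N(C)C)ccc3CNC(=O)c3ccc(Cl)s3)sc2C1`: 830 ug/mL
compound 2 `CN1CCc2nc(C(=O)Nc3cc(C(=O)NS(C)(=O)=O)ccc3CNC(=O)c3ccc(Cl)s3)sc2C1`: 1000 ug/mL
compound 3 `CNC(=O)c1ccc(CNC(=O)c2ccc(Cl)s2)c(NC(=O)c2nc3c(s2)CN(C)CC3)c1`: 2.7 ug/mL

Compound 2 and compound 1 form the upper pair of these three numbers, with a 1.2-fold higher number from compound 1 to compound 2 (0.08 log units; within the scatter). Compound 3 stands far from that pair, with a 370-fold lower number from compound 2 to compound 3 (2.57 log units; beyond the scatter) and a 310-fold lower number from compound 1 to compound 3 (2.49 log units; beyond the scatter).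

Still unmeasured is compound 4 `CN1CCc2nc(C(=O)Nc3cc(-c4nnn[nH]4)ccc3CNC(=O)c3ccc(Cl)s3)sc2C1`, with the change (1H-tetrazol-5-yl in place of (methylsulfonyl)carbamoyl on an aromatic carbon). In words, this is 1H-tetrazol-5-yl in place of (methylsulfonyl)carbamoyl on an aromatic carbon, para to a (((5-chlorothiophen-2-yl)carbonyl)amino)methyl group.

For the measured compounds named here, no measured step brings a 1H-tetrazol-5-yl group into this place, so the evidence is indirect. The steps show that the same place can give either a step within the scatter or a large one. Only compound 3 falls away from the upper pair, so three compounds give no firm rule. The entering group matches the leaving group in its hydrogen-bond donors and acceptors. Compound 4 is therefore expected to stay with the upper pair rather than drop towards compound 3 at 2.7 ug/mL, though that drop cannot be excluded.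

The expected change is a 1.7-fold lower number from compound 2 to compound 4 (0.22 log units; within the scatter), so no step beyond the scatter is expected. For compound 4 the estimated value is 600 ug/mL, with an expected range of 100 ug/mL to 2000 ug/mL.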

Compound 4, solubility: 470 ug/mL
Beside the measured number, compound 4's estimate is 1.3-fold (0.11 log units) above it; the measured number falls inside the stated range.
By their numbers in this assay, from the lowest: compound 3; then compounds 4, 1 and 2 (each within the scatter of the next, the first and the last beyond it).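

At this aromatic carbon, para to a (((5-chlorothiophen-2-yl)carbonyl)amino)methyl group, a five-membered aromatic ring with 4 hetero atoms now stands in place of the amide-type groups, and in this assay this change gives a 2.1-fold lower number from compound 2 to compound 4 (0.33 log units; beyond the scatter), a modest step, and a 1.8-fold lower number from compound 1 to compound 4 (0.25 log units; within the scatter). Set against the methylcarbamoyl group, the same ring gives a 170-fold higher number from compound 3 to compound 4 (2.24 log units; beyond the scatter), so among these four compounds the low number stays confined to that single group. Matching hydrogen-bond donor and acceptor counts in the leaving and entering groups thus go with a step beyond the scatter, though not with a fall towards the number of compound 3.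

Nothing on hand bears on the cause of these differences. Open, going by these compounds, is how a carboxylic acid or a primary amine at this aromatic carbon would stand in this assay, and whether the low number of compound 3 carries over to a longer chain on the amide nitrogen, such as ethylcarbamoyl.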